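Chloro for hydrogen carried from one core to another

A few compounds are considered here, and "the series" means these few. Any claim that something is new, unique, unknown or untested is made for them only; others in the source may bear on it.

Measured so far, in a functional assay on MCF7 cells (Homo sapiens) for inhibition, read by MTT assay, with a stated time of 48 h; a lower number here means a stronger inhibitor, a higher number a weaker inhibitor:
compound 1, `N#Cc1c(-c2ccccc2)nc2c(c(-c3ccccc3)nn2-c2ccccc2)c1-c1ccc(N2CCCCC2)cc1`: 27000 nM
compound 2, `N#Cc1c(-c2ccc(Cl)cc2)nc2c(c(-c3ccccc3)nn2-c2ccccc2)c1-c1ccc(N2CCCCC2)cc1`: 10600 nM
compound 3, `O=C(C=CNc1cc(-c2ccccc2)nn1-c1ccccc1)c1ccccc1`: 9650 nM

Compound 2 differs from compound 1 by chloro in place of hydrogen on an aromatic carbon. That single change gave a 2.5-fold lower number from compound 1 to compound 2 (0.41 log units; beyond the scatter). Compound 3 is built on a different core; the difference between the two cores is not broken down here. Compound 3 gives the lowest number of the three, but its value and that of compound 2 lie within the scatter of each other, so no order between them is claimed; only compound 1 stands apart from compound 3 beyond the scatter.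

Compound 4, `O=C(C=CNc1cc(-c2ccccc2)nn1-c1ccccc1)c1ccc(Cl)cc1`, is not yet measured. It differs from compound 3 by chloro in place of hydrogen on an aromatic carbon, the same change that was made from compound 1 to compound 2. Because the earlier step was a 2.5-fold lower number from compound 1 to compound 2 (0.41 log units; beyond the scatter), a step of similar direction is expected from compound 3 to compound 4 in this assay, estimated as a 1.9-fold lower number from compound 3 to compound 4 (0.29 log units; within the scatter), though the core is different and the earlier step is only modest, so a smaller shift would not surprise. For compound 4 the estimate is 5000 nM, expected to fall between 2000 nM and 12000 nM.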

Compound 4, half-maximal inhibitory concentration: 8070 nM
For compound 4 the middle estimate is 1.6-fold (0.21 log units) below the measured one; the measured number falls inside the stated range.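

In this assay, chloro in place of hydrogen on the core of compound 3 gives a 1.2-fold lower number from compound 3 to compound 4 (0.08 log units; within the scatter), so on this core alone the change has no effect that can be told from the scatter. Set beside the earlier step on the core of compound 1, the new step does not differ from it beyond what two such steps allow: the same change on two cores in this assay, a 2.5-fold lower number (0.41 log units; beyond the scatter) from compound 1 to compound 2 and a 1.2-fold lower number (0.08 log units; within the scatter) from compound 3 to compound 4, 2.1-fold (0.33 log units) apart, within the scatter of two such steps. The pair therefore does not show that the step seen on the core of compound 1 carries over to the core of compound 3, nor that it is lost there, and a single step on each core supports no claim that the two cores respond differently.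

Still open, as far as these compounds go, is whether another group in place of chloro, such as fluoro, methoxy, an amine or a carboxylic acid, would give a step beyond the scatter on both cores. Also open, from the compounds shown here alone, is whether the two cores would track each other across such a set of replacements, which one pair of steps cannot tell.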